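The compounds below may be only part of what the source reports. "The series", "measured", "known", "first", "only" and "open" are said of these compounds alone.

Measured compounds:
Compound 1 `CCCCC(Sc1ccc(OCCCOc2cccc(C)c2)cc1)C(=O)O` gives 4800 nM in an assay on isolated protein for inhibition of Polyunsaturated fatty acid 5-lipoxygenase (Homo sapiens), read by HPLC, with a stated time of 15 min, in the presence of a further agent that is not named here; on this read-out lower numbers stand for stronger inhibition and higher numbers for weaker inhibition.
Compound 2 `Cc1cccc(OCCCOc2ccc(SCC(=O)O)cc2)c1C` gives > 10000 nM in this assay, which is a limit of the measurement and not a number.

Compound 1 therefore holds the only numerical reading shown; the other entry sits at the limit of > 10000 nM in this assay, at which 1 of the 2 values shown sits. Compound 3 `CCCCC(Sc1ccc(OCCCOc2cccc(C(C)C)c2)cc1)C(=O)O` has not yet been measured. It differs from compound 1 by isopropyl in place of methyl on an aromatic carbon. Among the measured compounds shown here, no measured pair isolates this change, so the step is expected to stay small, within the usual scatter. The step from compound 1 to compound 3 is estimated as a 1.4-fold lower number from compound 1 to compound 3 (0.14 log units; within the scatter). Compound 3 is expected to give 3500 nM, within a range from 900 nM to 12000 nM.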

Compound 3, half-maximal inhibitory concentration: 1400 nM
For compound 3 the middle estimate is 2.5-fold (0.40 log units) above the measured one; measured number inside the range.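

Compounds 1 and 3 form the only pair shown that isolates a change at this place, on an aromatic carbon meta to a large group. In this assay, going from 3-methylphenyl to 3-isopropylphenyl gives a 3.4-fold lower number from compound 1 to compound 3 (0.54 log units; beyond the scatter), so the larger alkyl group is accepted here and the reading moves beyond the scatter. Nothing shown accounts for this step.

As far as these compounds go, whether a tert-butyl group would move the number further in the same direction stays open. So does the outcome for a methoxy group or an amine at this place.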